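This account rests on a few compounds, and the source may have more. Where it says the series, first, only, none or still open, it means among the compounds named here.

Measured so far in a functional assay (strain AB) with Danio rerio as the target, read by microscopy, with a stated time of 1 h; a higher number here means that more compound is needed for the effect, a lower number that less compound is needed:

Compound 1 `CC(C)(C)OC(=O)N1CCc2c(sc(NC(=O)Nc3ccc(Cl)cc3)c2C(N)=O)C1` — compound 1 gives > 25000 nM, a limit of the assay.
Compound 2 `CCC(C)(C)C1CCc2c(sc(NC(=O)Nc3ccc(Cl)cc3)c2C(N)=O)C1` — compound 2 gives > 25000 nM, a limit of the assay.
Compound 3 `CCC1CCc2c(sc(NC(=O)Nc3ccc(Cl)cc3)c2C(N)=O)C1` — compound 3 gives > 25000 nM, a limit of the assay.

Compound 3 stands on a limit only in this assay. Among the compounds with values here, the two further values shown are limits as well, so that all three values sit at the limit of > 25000 nM in this assay, at which 3 of the 3 values shown sit; no compound has yet given a number.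

Within the data shown here, the one measured step that touches compound 3 is a step that the two limits leave unreadable from compound 2 to compound 3, which the two limits leave unreadable in size and direction.

Compound 4 `NC(=O)c1c(NC(=O)Nc2ccc(Cl)cc2)sc2c1CCCC2` is to be measured in this assay. It differs from compound 3 by hydrogen in place of ethyl on a saturated ring carbon.

Among the measured compounds shown here, no measured step is readable, so there is nothing that points to a change in this assay beyond the scatter, and nothing that points to a reading below the limit. The expectation for compound 4 is therefore that the assay again reports a limit, and the step from compound 3 to compound 4 is expected as a step that the limit leaves unreadable from compound 3 to compound 4. For compound 4 the estimate is 30000 nM, in the range 10000 nM to 100000 nM.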

Compound 4, half-maximal effective concentration: > 25000 nM
Compound 4 was reported as a limit; the forecaster's own chance of this, stated with the estimate: 85%; the middle value lies beyond the limit too.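

In this assay compound 4 gives > 25000 nM, a limit of the assay. The steps from compound 2 and compound 3 to compound 4 cannot be read: the limit of > 25000 nM in this assay, at which 4 of the 4 values shown sit.

The compounds shown leave open whether any group on the saturated ring carbon, or any other change to the shared core, gives a number in this assay.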